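A few compounds are considered here, and "the series" means these few. Any claim that something is new, unique, unknown or untested is made for them only; others in the source may bear on it.

Of the compounds shown here, three sharing one core have so far been tested in an in vitro ADME assay on microsomes from liver (Homo sapiens) for metabolic stability, tested at 5 uM; a lower number here means that the compound disappears faster, a higher number that the compound lasts longer. Compound 1 `CC(C)CCn1nc(-c2cccs2)c(O)c(C2=NS(=O)(=O)c3cc(NS(=O)(=O)C4CC4)ccc3N2)c1=O` gives > 1 h, which is a limit of the assay and not a number. Compound 2 `CS(=O)(=O)Nc1ccc2c(c1)S(=O)(=O)N=C(c1c(O)c(-c3ccc(Cl)s3)nn(CCC3CC3)c1=O)N2` gives > 1 h, again a limit. On these data alone, compound 3 `CS(=O)(=O)Nc1ccc2c(c1)S(=O)(=O)N=C(c1c(O)c(-c3cccs3)nn(CCC3CC3)c1=O)N2` gives > 1 h, also a limit, so its true half-life remains unknown. The whole picture so far is the limit of > 1 h in this assay, at which 3 of the 3 values shown sit.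

Compound 4 `CS(=O)(=O)Nc1ccc2c(c1)S(=O)(=O)N=C(c1c(O)c(-c3cccs3)nn(CC3CC3)c1=O)N2` differs from compound 3 in one place: cyclopropyl in place of cyclopropylmethyl on a saturated chain carbon bound to an aromatic nitrogen. This puts cyclopropyl in place of cyclopropylmethyl on a saturated chain carbon bound to an aromatic nitrogen. For the measured compounds named here, the only measured step is a step that the two limits leave unreadable from compound 2 to compound 3, and it involves a different change, hydrogen in place of chloro on an aromatic carbon. It therefore offers no size and no direction to carry over to this change. The expectation in this assay is none beyond the scatter, and the estimated move is a step that the limit leaves unreadable from compound 3 to compound 4. Compound 4 is estimated at 1.5 h, with an expected range from 0.8 h to 4 h.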

Compound 4, half-life: > 1 h
Compound 4: a limit, no number; the forecaster's own chance of this, stated with the estimate: 80%; the middle value is on the limit's open side.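

In this assay compound 4 gives > 1 h, a limit and not a number, so the change from compound 3 to compound 4 cannot be read as a step. The compounds shown leave open how long each one truly lasts and whether any change among them matters, because all sit at one point: the limit of > 1 h in this assay, at which 4 of the 4 values shown sit.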